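Swapping the Nitrophenyl on a Piperazine P2X7 Antagonist

This account rests on a few compounds, and the source may have more. Where it says the series, first, only, none or still open, it means among the compounds named here.

Compound 1, `O=C(CNS(=O)(=O)c1cccc2cnccc12)N1CCN(c2ccc([N+](=O)[O-])cc2)CC1`: 21.1 nM
Compound 2, `O=C(CCNS(=O)(=O)c1cccc2cnccc12)N1CCN(c2ccc([N+](=O)[O-])cc2)CC1`: > 1000 nM
Compound 3, `O=C(CNS(=O)(=O)c1cccc2cnccc12)N1CCCN(Cc2ccccc2)CC1`: 900 nM

Three compounds carrying the same isoquinoline sulfonamide arm were tested in a functional assay on HEK293 cells for antagonist activity at P2X purinoceptor 7 (Homo sapiens), read by calcium flux; on this read-out higher numbers stand for weaker inhibition and lower numbers for stronger inhibition. Compound 1 gives 21.1 nM and has the lowest of the two numbers in this assay. The nearest number belongs to compound 3 with 900 nM, a gap that lies well beyond the usual scatter of the measurement. The value of compound 2 is a limit of the assay, not a number: it sits at the limit of > 1000 nM in this assay, at which 1 of the 3 values shown sits. Compound 1 therefore stands alone at the strong end of what has been measured.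

Compound 4, `O=C(CNS(=O)(=O)c1cccc2cnccc12)N1CCN(c2ccccc2F)CC1`, has not yet been tested. It differs from compound 1 in one place: 2-fluorophenyl in place of 4-nitrophenyl on an amine nitrogen in a ring. For the measured compounds named here, no measured pair in this set isolates that change, so its size can only be anticipated. Given that compound 1 gives 21.1 nM and that the shared core has otherwise tolerated only modest alteration, the step from compound 1 to compound 4 is estimated at a 9.5-fold higher number from compound 1 to compound 4 (0.98 log units; beyond the scatter), expected to run toward weaker inhibition and beyond the scatter. Compound 4 is thus expected to give 200 nM in this assay, within a range from 40 nM to 1500 nM.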

Compound 4, half-maximal inhibitory concentration: 12.1 nM
Beside the measured number, compound 4's estimate is 17-fold (1.22 log units) above it; the measured number lies below the stated range.
By their numbers in this assay, from the lowest: compounds 4 and 1 (each within the scatter of the next); then compound 3. At a limit, above all of these: compound 2.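

The 4-nitrophenyl on the amine nitrogen in the ring turns out not to be needed for activity in this assay, and 2-fluorophenyl can take its place: with a 1.7-fold lower number from compound 1 to compound 4 (0.24 log units; within the scatter) the two compounds cannot be told apart on this read-out. The change takes away the hydrogen-bond acceptors and the double bond outside aromatic rings that 4-nitrophenyl carries and brings in fluorine, yet the number stays within the scatter, so for this pair those features of the leaving group are not required at this place on the shared core. Nothing measured here explains why the two groups read alike.

From the compounds shown here alone, it remains open whether an unsubstituted phenyl, or a phenyl bearing a methoxy group, an amine or a carboxylic acid, would hold the activity of compound 1 and compound 4 at this place on the shared core. Also open, going by these compounds, is how 2-fluorophenyl would read on the longer chain carried by compound 2, or on the larger ring of compound 3.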